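Fluoro to methyl on the aryl group of compound 2

This account rests on a few compounds, and the source may have more. Where it says the series, first, only, none or still open, it means among the compounds named here.

Compound 1 `CCCC#Cc1cc([C@@H]2O[C@H](CO)[C@@H](O)[C@H]2O)n2ncnc(N)c12` in a functional assay on NCI-H460 cells (Homo sapiens) for antiproliferative activity, with a stated time of 72 h (on this read-out higher numbers stand for weaker inhibition and lower numbers for stronger inhibition), gives 400 nM. Compound 2 `Nc1ncnn2c([C@@H]3O[C@H](CO)[C@@H](O)[C@H]3O)cc(-c3ccccc3F)c12` differs by 2-fluorophenyl in place of pent-1-yn-1-yl on an aromatic carbon, a change that gave an at least 250-fold higher number from compound 1 to compound 2 (2.39 log units; beyond the scatter). In this assay compound 2 reaches only a limit, > 100000 nM, so its true value is not known. Compound 3 `Cc1ccccc1-c1cc([C@@H]2O[C@H](CO)[C@@H](O)[C@H]2O)n2ncnc(N)c12` carries methyl in place of fluoro on an aromatic carbon. Among the compounds with values here, no measured step covers this change; only the weak result of compound 2 is available. Compound 3 is therefore expected to stay weak, with an at least 1.6-fold lower number from compound 2 to compound 3 (0.22 log units; that floor lies within the scatter). Compound 3 is estimated at 60000 nM, between 5000 nM and 200000 nM.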

Compound 3, half-maximal inhibitory concentration: > 100000 nM
Compound 3 ended at the assay's limit (the forecaster's own chance of this, stated with the estimate: 55%); middle value at least 1.6-fold (0.22 log units) from the limit.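

Putting 2-methylphenyl in place of pent-1-yn-1-yl gave an at least 250-fold higher number from compound 1 to compound 3 (2.39 log units; beyond the scatter) in this assay, so the loss seen with 2-fluorophenyl is not confined to the fluoro group. Compound 3 also reaches only a limit, > 100000 nM. Methyl and fluoro cannot be ranked on this aromatic carbon, and the step between compound 2 and compound 3 cannot be read, because both compounds sit at the same limit: the limit of > 100000 nM in this assay, at which 2 of the 3 values shown sit.

Going by these compounds, it remains open whether an unsubstituted phenyl or a 2-methoxyphenyl would fare any better. On these data alone, it is equally open whether a shorter or longer alkynyl chain would come close to compound 1 at 400 nM.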